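Swapping the Five-Membered Ring: Expected Effect on Stability

The compounds below may be only part of what the source reports. "The series", "measured", "known", "first", "only" and "open" are said of these compounds alone.

Three compounds that share one core and differ only in a small saturated ring attached to a saturated ring carbon have been tested in an ADME assay on microsomes from liver (Mus musculus) for metabolic stability, with a stated time of 30 min; on this read-out lower numbers stand for a less stable compound and higher numbers for a more stable compound. Compound 1 `Cc1nc(N2CCC(N3CCOC3=O)CC2)nc2ccc(NC(=O)/C=C/c3ccc(OC(F)(F)F)cc3)cc12` gives 74%, compound 2 `Cc1nc(N2CCC(N3CCNC3=O)CC2)nc2ccc(NC(=O)/C=C/c3ccc(OC(F)(F)F)cc3)cc12` gives 89%, and compound 3 `Cc1nc(N2CCC(N3CCCS3(=O)=O)CC2)nc2ccc(NC(=O)/C=C/c3ccc(OC(F)(F)F)cc3)cc12` gives 83%. Compound 3 stands second highest of the three, and both of its steps, a number 9 percentage points higher from compound 1 to compound 3 (within the scatter) and a number 6 percentage points lower from compound 2 to compound 3 (within the scatter), lie within the scatter; only a number 15 percentage points higher from compound 1 to compound 2 (beyond the scatter) counts as a modest change beyond it. Compound 4 `Cc1nc(N2CCC(N3C(=O)CCC3=O)CC2)nc2ccc(NC(=O)/C=C/c3ccc(OC(F)(F)F)cc3)cc12` carries the next variation: a group of 7 heavy atoms (4 carbon, 1 nitrogen, 2 oxygen; one five-membered non-aromatic ring with 1 hetero atom) in place of a group of 7 heavy atoms (3 carbon, 1 nitrogen, 2 oxygen, 1 sulfur; one five-membered non-aromatic ring with 2 hetero atoms), on a saturated ring carbon. The two steps that bear on such a swap of one five-membered ring for another, a number 9 percentage points higher from compound 1 to compound 3 (within the scatter) and a number 6 percentage points lower from compound 2 to compound 3 (within the scatter), were both within the scatter, so no step beyond the scatter is expected in this assay here either. Compound 4 is therefore estimated at 78%, with an expected range from 62% to 92%. That estimate corresponds to an expected step of a number 5 percentage points lower from compound 3 to compound 4 (within the scatter).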

Compound 4, percent of the compound remaining: 40%
Compound 4: the middle estimate sits 38 percentage points above what was measured; the measured number lies below the stated range.
By their numbers in this assay, from the lowest: compound 4; then compounds 1, 3 and 2 (each within the scatter of the next, the first and the last beyond it).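

At this saturated ring carbon in this assay, the identity of the five-membered ring matters far more than the first three compounds suggested: placing 2,5-dioxopyrrolidin-1-yl here gives a number 43 percentage points lower from compound 3 to compound 4 (beyond the scatter) and a number 49 percentage points lower from compound 2 to compound 4 (beyond the scatter) and also a number 34 percentage points lower from compound 1 to compound 4 (beyond the scatter) in this read-out. Between compound 3 and compound 4, the entering and leaving groups have the same counts of heavy atoms, hydrogen-bond donors and hydrogen-bond acceptors, so these counts alone do not separate the two results. Nothing available here explains the drop.

A 2-oxopyrrolidin-1-yl group, with a single carbonyl in the ring, would help show whether the low number goes with the second carbonyl. Also open, going by these compounds, are the site in the molecule where the compound is lost and whether a six-membered 2,6-dioxopiperidin-1-yl group would behave the same way.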